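The source may report more compounds than this note shows. Statements on the series, on what has been measured and on what is new or still open speak of the compounds shown alone.

Measured so far in an ADME assay on THP-1 cells (Homo sapiens) for cytotoxicity; on this read-out lower numbers stand for higher toxicity in this test and higher numbers for lower toxicity in this test:
- compound 1 `COC(=O)Nc1sc2c(c1C(=O)Nc1ccc(OC)cc1)CCCCC2`: > 50000 nM
- compound 2 `COc1ccc(CNC(=O)c2c(NC(=O)C(F)(F)F)sc3c2CCCCC3)cc1`: > 50000 nM

Both readings are limits of the assay and not numbers, so compound 1 has no exact position on this scale. The evidence so far is the limit of > 50000 nM in this assay, at which 2 of the 2 values shown sit. Compound 3 `COc1ccc(NC(=O)c2c(NC(=O)c3ccccc3)sc3c2CCCCC3)cc1` is next, with phenyl in place of methoxy on a carbonyl carbon. No measured step sizes this change, and the expectation in this assay rests only on the limit of > 50000 nM in this assay, at which 2 of the 2 values shown sit: no step beyond the scatter is expected. The expected step is an at least 1.1-fold lower number from compound 1 to compound 3 (0.04 log units; that floor lies within the scatter). For compound 3 the estimated value is 45000 nM, within an expected range of 15000 nM to 50000 nM.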

Compound 3, half-maximal cytotoxic concentration: > 50000 nM
Compound 3: a limit, no number; the forecaster's own chance of this, stated with the estimate: 70%; at least 1.1-fold (0.04 log units) between middle value and limit.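

Compound 1 and compound 3 both read as limits in this assay, so no step can be read between them. Still open is where any compound shown lies on this scale, and whether phenyl in place of methoxy on a carbonyl carbon shifts the read-out.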